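Swapping the aryl group on a pyrazole-based cytotoxicity series

This account rests on a few compounds, and the source may have more. Where it says the series, first, only, none or still open, it means among the compounds named here.

Measured so far:
Compound 1, `Cc1ccccc1-c1nn(-c2ccc(Br)cc2)cc1CNCCN1CCN(C)CC1`: 9600 nM
Compound 2, `CN1CCN(CCNCc2cn(-c3ccc(F)cc3F)nc2-c2cccc(Cl)c2)CC1`: 15000 nM

Both were tested in an ADME assay on Huh-7 cells (Homo sapiens) for cytotoxicity; a lower number here means that less compound is tolerated, a higher number that more compound is tolerated. For the measured compounds named here, of the two numbers, the one for compound 2 is the upper one, yet the gap to compound 1 lies within the usual scatter, so the two cannot be told apart.

Compound 3, `CN1CCN(CCNCc2cn(-c3ccc(F)cc3F)nc2-c2ccc(N(C)C)cc2)CC1`, is not yet measured. It differs from compound 2 in one place: 4-(dimethylamino)phenyl in place of 3-chlorophenyl on an aromatic carbon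

Going by the values given here, no measured pair shows what this change does. With nothing beyond the scatter between the two known compounds, the step of no change at the digits printed from compound 2 to compound 3 (within the scatter) is expected to stay within the scatter, in no clear direction. Compound 3 is therefore estimated at 15000 nM, with a range from 6000 nM to 40000 nM.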

Compound 3, half-maximal cytotoxic concentration: > 20000 nM
Compound 3: only a limit was reported; the forecaster's own chance of this, stated with the estimate: 10%; at least 1.3-fold (0.12 log units) between middle value and limit.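

For the compounds shown here, at this position, 4-(dimethylamino)phenyl can replace 3-chlorophenyl with no sign that less compound is tolerated in this assay. Compound 3 gives > 20000 nM, which is a limit of the assay and not a number. The change gives an at least 1.3-fold higher number from compound 2 to compound 3 (0.12 log units; that floor lies within the scatter), and its full size stays hidden because the read-out for compound 3 is only a limit: the limit of > 20000 nM in this assay, at which 1 of the 3 values shown sits.

Still open, going by these compounds, is whether a plain amino group or a carboxylic acid on the phenyl ring would give a value inside the measurable range. The compounds shown also do not separate the swap of chlorine for dimethylamino from the shift in where the group sits on that ring.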